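Replacing 4-Methoxyphenyl with 3-Methylfuran-2-yl on the Core

The source may hold more compounds than are shown below. What is called first, only, known or untested is meant among the compounds shown, and "the series" means these compounds.

In a functional assay on Ehrlich cells (Mus musculus) for antiproliferative activity, read by trypan blue exclusion, with a stated time of 2 h, tested at 25 ug/mL (on this read-out lower numbers stand for a weaker effect and higher numbers for a stronger effect at the one concentration tested), the three measured compounds gave these numbers:
compound 1, `N#CC1=C(N)N(c2ccc(S(N)(=O)=O)cc2)C2=C(C(=O)CCC2)C1c1ccccc1`: 30%
compound 2, `COc1ccc(C2C(C#N)=C(N)N(c3ccc(S(N)(=O)=O)cc3)C3=C2C(=O)CCC3)cc1`: 50%
compound 3, `COc1cc(CC2C(C#N)=C(N)N(c3ccc(S(N)(=O)=O)cc3)C3=C2C(=O)CCC3)ccc1O`: 50%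

Compound 2 shares the top of this small set with compound 3, as no change at the digits printed from compound 2 to compound 3 (within the scatter) shows, and stands well above compound 1, as a number 20 percentage points higher from compound 1 to compound 2 (beyond the scatter) shows. Compound 4, `Cc1ccoc1C1C(C#N)=C(N)N(c2ccc(S(N)(=O)=O)cc2)C2=C1C(=O)CCC2`, is not yet measured. It differs from compound 2 by 3-methylfuran-2-yl in place of 4-methoxyphenyl on a saturated ring carbon.

Two measured steps also exchange the group on that saturated ring carbon: a number 20 percentage points higher from compound 1 to compound 3 (beyond the scatter) was a modest rise, and no change at the digits printed from compound 2 to compound 3 (within the scatter) was no change. Neither step introduces a five-membered aromatic ring, so the data give no direct guide for that. Because no change at the digits printed from compound 2 to compound 3 (within the scatter) shows the saturated ring carbon tolerating a different group without change, the expected step is a number 5 percentage points lower from compound 2 to compound 4 (within the scatter), small and within the scatter. Compound 4 is therefore estimated at 45%, with a range from 25% to 65%.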

Compound 4, a percentage reported as activity, at one concentration (the size of the read-out at that concentration, not a potency): 10%
Compound 4: middle estimate off by 35 percentage points, on the high side; the whole stated range lies above it.
By their numbers in this assay, from the lowest: compound 4; then compound 1; then compounds 2 and 3 (each within the scatter of the next).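

Until now, the groups on the saturated ring carbon had given only a rise or no change, but in this assay the 3-methylfuran-2-yl group brings a number 40 percentage points lower from compound 2 to compound 4 (beyond the scatter) and a number 40 percentage points lower from compound 3 to compound 4 (beyond the scatter), so this position does not treat every aromatic group alike. The new group also falls short of plain phenyl, with a number 20 percentage points lower from compound 1 to compound 4 (beyond the scatter), which makes compound 4 the weakest of the four at the one concentration tested. Nothing measured on these compounds gives a reason for this fall.

The compounds shown do not separate the effect of the five-membered ring from that of its methyl group. A furan-2-yl group without the methyl would test the methyl on its own, and a thiophen-2-yl group would test the ring oxygen.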